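The compounds below may be only part of what the source reports. "The series", "measured", "known", "first", "only" and "open" are said of these compounds alone.

Measured so far in a functional assay on CRL2813 cells (Homo sapiens) for cytotoxicity, read by sulforhodamine B assay, with a stated time of 5 days; a lower number here means a stronger inhibitor, a higher number a weaker inhibitor:
Compound 1 `O=C(Nc1ccc(I)cc1)N[C@H]1CC[C@H](Oc2ccc(F)cc2)CC1`: 10200 nM
Compound 2 `O=C(Nc1cccc([N+](=O)[O-])c1)N[C@H]1CC[C@H](Oc2ccc(F)cc2)CC1`: 6700 nM

Among these two numbers compound 1 gives the highest one in this assay. Within the data shown here, its nearest neighbour is compound 2, and the only measured step, a 1.5-fold lower number from compound 1 to compound 2 (0.18 log units; within the scatter), is a change of the substituted aromatic ring on the urea-type nitrogen that stays within the scatter. The new compound 3 `COC(=O)c1ccc(NC(=O)N[C@H]2CC[C@H](Oc3ccc(F)cc3)CC2)cc1` differs from compound 1 in one place as well: methoxycarbonyl in place of iodo on an aromatic carbon. Among the measured compounds shown here, the one measured step that bears on this kind of change, a 1.5-fold lower number from compound 1 to compound 2 (0.18 log units; within the scatter), shows that swapping one substituent pattern on that aryl ring for another left the number where it was, within the scatter. For the measured compounds named here, no measured compound carries a methoxycarbonyl group, so nothing speaks directly for this group, and the available evidence points to no step beyond the scatter in this assay. Compound 3 is therefore expected to give about 8000 nM in this assay, with a range from 3000 nM to 25000 nM. For compound 3 this estimate corresponds to an expected step of a 1.3-fold lower number from compound 1 to compound 3 (0.11 log units; within the scatter).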

Compound 3, half-maximal inhibitory concentration: 11600 nM
The estimate for compound 3 lay 1.5-fold (0.16 log units) below the measured number; low and high end bracket the measured number.
By their numbers in this assay, from the lowest: compounds 2, 1 and 3 (each within the scatter of the next).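

In this assay, the step from iodo to methoxycarbonyl on the aromatic carbon para to a large group is a 1.1-fold higher number from compound 1 to compound 3 (0.06 log units; within the scatter) and so stays inside the usual spread of repeat measurements. The earlier step replaced 4-iodophenyl with 3-nitrophenyl, so the group and its place on the ring changed together, whereas here the place stays the same and only the group changes. Iodo is a single heavy atom with no hydrogen-bond acceptors and methoxycarbonyl brings 4 heavy atoms, a double bond and 2 hydrogen-bond acceptors, yet this difference in make-up goes with no step beyond the scatter, and no measurement shown here explains that result.

The compounds shown leave open whether an amine or a carboxylic acid on this aromatic carbon would give a step beyond the scatter, or whether a longer chain there would do so. They also leave open whether methoxycarbonyl would give the same result elsewhere on the aromatic ring, and whether any change outside that ring would move the number further.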